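One Bromine in Place of Two Hydroxyls: Expected Cytotoxicity

This account rests on a few compounds, and the source may have more. Where it says the series, first, only, none or still open, it means among the compounds named here.

Measured so far:
- compound 1 `CN(C)CCn1cnnc1-c1cc(Oc2ccc(NC(=O)N/N=C/c3c(Cl)cccc3Cl)cc2F)ccn1` gives 3320 nM in an ADME assay on WI-38 cells (Homo sapiens) for cytotoxicity, read by MTT assay, with a stated time of 72 h; on this read-out lower numbers stand for stronger inhibition and higher numbers for weaker inhibition
- compound 2 `CN(C)CCn1cnnc1-c1cc(Oc2ccc(NC(=O)N/N=C/c3ccccc3)cc2F)ccn1` is recorded as "not determined" (no result reported) in this assay, so it has no reported result
- compound 3 `CN(C)CCn1cnnc1-c1cc(Oc2ccc(NC(=O)N/N=C/c3ccc(O)c(O)c3)cc2F)ccn1` is recorded as "not determined" (no result reported) in this assay, so it has no reported result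

Compound 3 therefore stands nowhere on the numbers: no half-maximal inhibitory concentration was reported for it, and the same is true of compound 2. Among the compounds with values here, the only anchor is compound 1.

Compound 4 `CN(C)CCn1cnnc1-c1cc(Oc2ccc(NC(=O)N/N=C/c3cccc(Br)c3)cc2F)ccn1` differs from compound 3 by 3-bromophenyl in place of 3,4-dihydroxyphenyl on a carbon with a double bond to nitrogen. Within the data shown here, with no measured step to lean on, the size and direction of this change in this assay cannot be read from the data, and nothing beyond the usual scatter can be claimed.

Compound 4 is expected to come out near 3000 nM, within a range of 700 nM to 13000 nM, a guess resting only on compound 1 at 3320 nM.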

Compound 4, half-maximal inhibitory concentration: 4230 nM
For compound 4 the middle estimate is 1.4-fold (0.15 log units) below the measured one; measured number inside the range.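

In this assay, within the data shown here, placing 3-bromophenyl instead of 2,6-dichlorophenyl on the carbon with a double bond to nitrogen gives a 1.3-fold higher number from compound 1 to compound 4 (0.11 log units; within the scatter), the first measured step at this position, and it shows that these two substituted rings cannot be told apart on this read-out. Compound 3 and compound 2 have no reported result, so the steps from them cannot be read, including the change from 3,4-dihydroxyphenyl to 3-bromophenyl. Nothing available explains this result. From the compounds shown here alone, whether an amine or a carboxylic acid on this ring would move the number remains open.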